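The source may report more compounds than this note shows. Statements on the series, on what has been measured and on what is new or still open speak of the compounds shown alone.

Working notes on the series. All compounds share the core of compound 1 `COc1cc2nc(NCCCN3CCCC3=O)nc(NC3CCCCCC3)c2cc1OC`, which in an in vitro assay on B300-19 cells for displacement of a labelled ligand from C-C chemokine receptor type 4 (Homo sapiens), tested at 1 uM (on this read-out higher numbers stand for more inhibition at the one concentration tested (going by the name of the read-out) and lower numbers for less inhibition), gives 8%. Compound 2 `COc1cc2nc(NCc3cccs3)nc(NC3CCCCCC3)c2cc1OC` reaches only a limit in this assay, < 0%. Compound 3 `COc1cc2nc(N3CCC(C(N)=O)CC3)nc(NC3CCCCCC3)c2cc1OC` likewise stands at a limit, < 0%, so its position is the floor of the read-out (the limit of < 0% in this assay, at which 2 of the 3 values shown sit). The readable steps are a number at least 8 percentage points lower from compound 1 to compound 2 (that floor lies within the scatter) and a number at least 8 percentage points lower from compound 1 to compound 3 (that floor lies within the scatter), while a step that the two limits leave unreadable from compound 2 to compound 3. Compound 4 `COc1cc2nc(NC(C)C)nc(NC3CCCCCC3)c2cc1OC` carries isopropylamino in place of 4-carbamoylpiperidin-1-yl on an aromatic carbon, on an aromatic carbon between two ring nitrogen atoms. For the measured compounds named here, no measured step involves an isopropylamino group, and the two readable steps both end at the floor. The step of a number at least 3 percentage points higher from compound 3 to compound 4 (that floor lies within the scatter) is therefore expected to stay within the scatter. Compound 4 is estimated at 3%, with a range from -5% to 14%.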

Compound 4, a percentage reported as inhibition, at one concentration (the size of the read-out at that concentration, not a potency): 6%
Compound 4: middle estimate off by 3 percentage points, on the low side, and the stated range covers the measured number.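

Replacing 4-carbamoylpiperidin-1-yl with isopropylamino gives a number at least 6 percentage points higher from compound 3 to compound 4 (that floor lies within the scatter), and replacing the thiophene-bearing group gives a number at least 6 percentage points higher from compound 2 to compound 4 (that floor lies within the scatter). In this assay, the isopropyl group also gives a number 2 percentage points lower from compound 1 to compound 4 (within the scatter), so dropping the 2-oxopyrrolidin-1-yl end of the chain produces no step beyond the scatter at this position. All changes here stay close to the floor of the read-out: the limit of < 0% in this assay, at which 2 of the 4 values shown sit.

On these data alone, whether a primary amine or a carboxylic acid on a longer chain at this aromatic carbon would give a step beyond the scatter remains open. So does the effect of replacing cycloheptylamino with a benzylamino group.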